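The compounds below may be only part of what the source reports. "The series", "measured", "known", "first", "only" and "open" are said of these compounds alone.

Measured compounds:
compound 1 `O=C(CN1CCC(c2cccc[n+]2[O-])CC1)Nc1cccc(Cl)c1Cl` with 180 nM
compound 2 `O=C(CN1CCC(c2cccc[n+]2[O-])CC1)Nc1cccc(Cl)c1` with 62 nM
compound 3 `CSc1cccc(NC(=O)CN2CCC(c3cccc[n+]3[O-])CC2)c1` with 100 nM

In a functional assay on HEK293 cells for agonist activity at D(4) dopamine receptor (Homo sapiens), read by FLIPR (a lower number here means that less compound is needed, a higher number that more compound is needed for the effect), compound 3 stands second highest of the three numbers; its nearest neighbour is compound 2, with a 1.6-fold higher number from compound 2 to compound 3 (0.21 log units; within the scatter), and its furthest is compound 1, with a 1.8-fold lower number from compound 1 to compound 3 (0.26 log units; within the scatter). Compound 4 `Cc1cccc(C)c1NC(=O)CN1CCC(c2cccc[n+]2[O-])CC1` differs from compound 3 by 2,6-dimethylphenyl in place of 3-(methylsulfanyl)phenyl on an amide-type nitrogen. Within the data shown here, the only step that exchanges the whole aryl group on that nitrogen is a 1.8-fold lower number from compound 1 to compound 3 (0.26 log units; within the scatter), and the substituent swaps a 2.9-fold lower number from compound 1 to compound 2 (0.46 log units; beyond the scatter) and a 1.6-fold higher number from compound 2 to compound 3 (0.21 log units; within the scatter) are also small. All changes to this aryl group have so far stayed small, so a step within or only modestly beyond the scatter is expected, with no firm direction. Compound 4 is therefore estimated at 150 nM in this assay, between 60 nM and 400 nM, corresponding to an expected 1.5-fold higher number from compound 3 to compound 4 (0.18 log units; within the scatter).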

Compound 4, half-maximal effective concentration: 346 nM
Compound 4: the middle estimate sits 2.3-fold (0.36 log units) below what was measured; low and high end bracket the measured number.
By their numbers in this assay, from the lowest: compounds 2, 3, 1 and 4 (each within the scatter of the next, the first and the last beyond it).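

In this assay, among these compounds, 2,6-dimethylphenyl on the amide-type nitrogen gives the first exchanges of this aryl group that lie beyond the scatter, with a 3.5-fold higher number from compound 3 to compound 4 (0.54 log units; beyond the scatter) and a 5.6-fold higher number from compound 2 to compound 4 (0.75 log units; beyond the scatter). Against 2,3-dichlorophenyl the same group stays within the scatter (a 1.9-fold higher number from compound 1 to compound 4 (0.28 log units; within the scatter)), so the size of the step depends on which aryl group it replaces. Nothing available here accounts for these differences.

The compounds shown do not separate the contributions of the two methyl groups in 2,6-dimethylphenyl. Going by these compounds, how a methoxy group or an amine on this aryl group, or a cyclohexyl group in its place, would read also remains open.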